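What a methoxy group may do to compound 1

The source may hold more compounds than are shown below. What is called first, only, known or untested is meant among the compounds shown, and "the series" means these compounds.

In a functional assay on cells (Mast cell, Rattus norvegicus) for inhibition, with a stated time of 15 min (a lower number here means that less compound is needed, a higher number that more compound is needed for the effect), compound 1 (`O=C(Nc1nnn[nH]1)c1cc(=O)c2ccccc2o1`) gives 0.08 ug/mL as its value. Compound 2 (`Cc1ccc2oc(C(=O)Nc3nnn[nH]3)cc(=O)c2c1`) gives 0.075 ug/mL and cannot be told apart from compound 1, while compound 3 (`CNc1c(C(=O)Nc2nnn[nH]2)oc2ccccc2c1=O`) gives 0.4 ug/mL as its value. Compound 1 thus sits level with compound 2 and under the number of compound 3.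

Compound 4 (`COc1ccc2c(=O)cc(C(=O)Nc3nnn[nH]3)oc2c1`) has the core of compound 1 but carries methoxy in place of hydrogen on an aromatic carbon. Two measured changes bear on this. Methyl in place of hydrogen on an aromatic carbon gave a 1.1-fold lower number from compound 1 to compound 2 (0.03 log units; within the scatter) and methylamino in place of hydrogen gave a 5.0-fold higher number from compound 1 to compound 3 (0.70 log units; beyond the scatter) so such a swap may change nothing or may cost some activity. Neither is methoxy itself, so in this assay only a small move towards a higher number is expected, most likely none beyond the scatter. The estimated step is a 1.3-fold higher number from compound 1 to compound 4 (0.10 log units; within the scatter) and it could prove larger. Compound 4 is expected to give 0.1 ug/mL as its value and to fall between 0.04 ug/mL and 0.3 ug/mL.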

Compound 4, concentration for half-maximal effect: 0.048 ug/mL
The estimate for compound 4 lay 2.1-fold (0.32 log units) above the measured number; the range from low to high includes it.
By their numbers in this assay, from the lowest: compounds 4, 2 and 1 (each within the scatter of the next); then compound 3.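

In this assay the move gives a 1.7-fold lower number from compound 1 to compound 4 (0.22 log units; within the scatter) and so counts as no real change: this carbon of the six-membered aromatic ring of carbon only accepts methoxy with no measurable gain or loss. The cost seen with methylamino, a 5.0-fold higher number from compound 1 to compound 3 (0.70 log units; beyond the scatter) on a different part of the core, does not appear with methoxy here, so a substituent on the shared core need not raise the number. No measurement at hand offers a reason for this result.

On these data alone, it remains open how far this tolerance goes, for example whether a hydroxyl, an ethoxy group, a longer chain or a carboxylic acid on the same carbon would also leave the number unchanged. Whether methoxy would behave the same way on the other carbons of this ring is also unknown.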